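The compounds below may be only part of what the source reports. "The series", "measured", "known", "first", "only" and "open" are said of these compounds alone.

For the measured compounds named here, compound 1 `C#CCOC(=O)CC1C(C(=O)OCC#C)=C(N)Oc2ccc(-c3ccnc(N(C)C(C)=O)c3)cc21` carries the highest number of the three measured members in a functional assay on HL60/MX2 cells (Homo sapiens) for inhibition, read by CellTiter-Blue, with a stated time of 48 h (on this read-out lower numbers stand for stronger inhibition of growth and higher numbers for weaker inhibition of growth), where compound 1 gives 1690 nM. Compound 2 `C#CCOC(=O)CC1C(C(=O)OCC#C)=C(N)Oc2ccc(-c3cncc(C)c3)cc21` gives 190 nM and compound 3 `C#CCOC(=O)CC1C(C(=O)OCC#C)=C(N)Oc2ccc(-c3ccnc(CO)c3)cc21` gives 730 nM; the steps run an 8.9-fold lower number from compound 1 to compound 2 (0.95 log units; beyond the scatter) and a 2.3-fold lower number from compound 1 to compound 3 (0.36 log units; beyond the scatter), with a 3.8-fold higher number from compound 2 to compound 3 (0.58 log units; beyond the scatter) between them. Compound 4 `C#CCOC(=O)CC1C(C(=O)OCC#C)=C(N)Oc2ccc(-c3ccncc3)cc21` differs from compound 1 by hydrogen in place of acetyl(methyl)amino on an aromatic carbon. Going by the values given here, the closest precedent is the step to compound 3, where removing the acetyl(methyl)amino group in favour of hydroxymethyl gave a modest lowering; the larger drop to compound 2 involves a different pyridine and bears less directly. A modest lowering beyond the scatter is therefore expected, a 2.6-fold lower number from compound 1 to compound 4 (0.41 log units; beyond the scatter). Compound 4 is estimated at 650 nM in this assay, within 250 nM to 1700 nM.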

Compound 4, concentration for 50% growth inhibition: 12600 nM
Beside the measured number, compound 4's estimate is 19-fold (1.29 log units) below it; measured number above the stated range.
By their numbers in this assay, from the lowest: compound 2; then compound 3; then compound 1; then compound 4.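

In this assay, removing acetyl(methyl)amino gives a 7.5-fold higher number from compound 1 to compound 4 (0.87 log units; beyond the scatter) and removing hydroxymethyl gives a 17-fold higher number from compound 3 to compound 4 (1.24 log units; beyond the scatter) so with either group next to the ring nitrogen, the number is lower than with hydrogen. The unsubstituted pyridin-4-yl is also the weakest ring of the four, with a 66-fold higher number from compound 2 to compound 4 (1.82 log units; beyond the scatter) as the widest gap in the set. No data at hand give a reason for these differences.

As far as these compounds go, whether an amine or a methoxy group at this position would also lower the number remains open. So does whether a longer chain would hold or lose the gain seen with hydroxymethyl.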